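Moving the carboxyl: 2-carboxyethyl to 1-carboxyethyl on an amine nitrogen

The compounds below may be only part of what the source reports. "The series", "measured", "known", "first", "only" and "open" are said of these compounds alone.

Within the data shown here, in a functional assay on K562 cells (Homo sapiens) for cytotoxicity, read by MTT assay, with a stated time of 72 h (on this read-out higher numbers stand for weaker inhibition and lower numbers for stronger inhibition), compound 1 `CC(C)(C)C1=CC(=O)C=C(NCCC(=O)O)C1=O` gives 67000 nM, the highest of the three numbers measured so far. Compound 2 `CC1=CCC[C@H]2[C@](C)(CC3=CC(=O)C=C(N[C@@H](CC(C)C)C(=O)O)C3=O)[C@@H](C)CC[C@]12C` gives 11200 nM, and compound 3 `CC1=CCC[C@H]2[C@](C)(CC3=CC(=O)C=C(N[C@@H](C(=O)O)C(C)C)C3=O)[C@@H](C)CC[C@]12C` gives 7780 nM. Both differ from compound 1 in more than the group on the amine nitrogen, so their distance from it says little here. Compound 4 `C[C@H](NC1=CC(=O)C=C(C(C)(C)C)C1=O)C(=O)O` carries 1-carboxyethyl in place of 2-carboxyethyl on an amine nitrogen. Among the measured compounds shown here, the only measured change confined to that nitrogen is a 1.4-fold lower number from compound 2 to compound 3 (0.16 log units; within the scatter), and it stays within the scatter. No shift beyond the scatter is therefore expected in this assay. The expected step is a 1.2-fold lower number from compound 1 to compound 4 (0.09 log units; within the scatter). Compound 4 is estimated at 55000 nM, with an expected range of 24000 nM to 120000 nM.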

Compound 4, half-maximal inhibitory concentration: 77600 nM
Estimate against measurement, compound 4: 1.4-fold (0.15 log units) below; the range from low to high includes it.
By their numbers in this assay, from the lowest: compounds 3 and 2 (each within the scatter of the next); then compounds 1 and 4 (each within the scatter of the next).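

In this assay, the carboxyl can sit on either carbon of this chain on the amine nitrogen without the two compounds being told apart, with a 1.2-fold higher number from compound 1 to compound 4 (0.06 log units; within the scatter). The earlier step confined to this nitrogen came from a different core, so this pair extends that reading to the core of compound 1, where the defined stereocentre of 1-carboxyethyl also leaves the result within the scatter. Nothing available explains why the two groups read alike.

Still open, going by these compounds, is whether a longer chain such as 3-carboxypropyl, or a methyl ester in place of the carboxylic acid, would separate from these values. On these data alone, the opposite stereocentre in 1-carboxyethyl also remains open.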